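Swapping the sulfamoylphenyl for a hydroxypyridinyl

The source may report more compounds than this note shows. Statements on the series, on what has been measured and on what is new or still open speak of the compounds shown alone.

Three compounds have been measured in an in vitro functional assay on HEK285-7 cells for antagonist activity at prostaglandin D2 receptor 2 (Homo sapiens), read by BRET and beta-arrestin recruitment; a higher number here means a weaker inhibitor, a lower number a stronger inhibitor:

compound 1, `O=C(O)Cc1sc(COc2ccc(Cl)cc2)nc1-c1ccc(Cl)cc1`, gives 370 nM
compound 2, `O=C(O)Cc1sc(C(c2ccccc2)c2ccc(Cl)cc2)nc1-c1ccc(F)cc1`, gives 79 nM
compound 3, `NS(=O)(=O)c1ccc(-c2nc(C(c3ccc(F)cc3)c3ccc(F)cc3)sc2CC(=O)O)cc1`, gives only a limit, > 100000 nM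

Compound 3 therefore stands apart from the other two: its result is not a number but the limit of the assay, and (the limit of > 100000 nM in this assay, at which 1 of the 3 values shown sits). Compound 1 and compound 2 both return numbers, and the gap between them is wider than the usual scatter.

The untested compound 4, `O=C(O)Cc1sc(C(c2ccc(F)cc2)c2ccc(F)cc2)nc1-c1ccnc(O)c1`, keeps the shared core and the bis(4-fluorophenyl)methyl group of compound 3 and differs from it in one place: 2-hydroxypyridin-4-yl in place of 4-sulfamoylphenyl on an aromatic carbon. Among the compounds with values here, no measured pair shows this change directly, so the expectation rests on the spread of the three values above, from the limit of compound 3 to the numbers of compound 1 and compound 2.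

Compound 4 is expected to move off the limit and into the measurable range, a step in the direction of stronger inhibition, an at least 12-fold lower number from compound 3 to compound 4 (1.09 log units; beyond the scatter), though without reaching the potency of compound 2. The estimate for compound 4 in this assay is 8000 nM, within 800 nM to 100000 nM.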

Compound 4, half-maximal inhibitory concentration: 890 nM
The estimate for compound 4 lay 9.0-fold (0.95 log units) above the measured number; the measured number falls inside the stated range.
By their numbers in this assay, from the lowest: compound 2; then compound 1; then compound 4. At a limit, above all of these: compound 3.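

In this assay, the aromatic carbon next to the ring nitrogen proves highly sensitive to the group it carries: with the bis(4-fluorophenyl)methyl group and the carboxymethyl group unchanged, 2-hydroxypyridin-4-yl in place of 4-sulfamoylphenyl gives an at least 110-fold lower number from compound 3 to compound 4 (2.05 log units; beyond the scatter). Within the data shown here, this is the first single-place comparison, and it shows that the bis(4-fluorophenyl)methyl compounds are not inactive as a class, since compound 4 gives 890 nM. Compound 3 gives a limit and not a number, so the step has a lower bound and its full size remains unknown: the limit of > 100000 nM in this assay, at which 1 of the 4 values shown sits.

The compounds shown leave open which feature of the exchange accounts for the step, since the ring nitrogen, the hydroxyl and the loss of the sulfamoyl group all change together, and a plain phenyl, a 4-hydroxyphenyl or a pyridin-4-yl group at the same carbon would begin to separate them. They also leave open whether the hydroxyl itself is needed, which a 2-methoxypyridin-4-yl or 2-aminopyridin-4-yl group at this carbon could test.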